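The source may report more compounds than this note shows. Statements on the series, on what has been measured and on what is new or still open speak of the compounds shown alone.

Of the compounds shown here, three have been measured in an assay for inhibition of Nicotinamide phosphoribosyltransferase (Homo sapiens), read by mass spectrometry, with stated times of 15 min and 30 min; a lower number here means a stronger inhibitor, a higher number a weaker inhibitor. Compound 2 `O=C(NCc1ccc(S(=O)(=O)N2CCCCC2)cc1)c1cnc2nccn2c1` gives 3 nM, compound 3 `O=C(NCc1ccc(S(=O)(=O)N2CCCCC2)cc1)c1cc2cccnc2s1` gives 8 nM, and compound 1 `O=C(NCc1ccc(S(=O)(=O)c2ccccc2C(F)(F)F)cc1)c1cc2cnccc2[nH]1` gives 24 nM, the highest of the three numbers, so compound 1 is the weakest inhibitor among them. Within the data shown here, the single measured step, a 2.7-fold higher number from compound 2 to compound 3 (0.43 log units; beyond the scatter), swaps the group on the carbonyl carbon and does not touch the part that is altered now. Compound 4 `Cc1ccccc1S(=O)(=O)c1ccc(CNC(=O)c2cc3cnccc3[nH]2)cc1` differs from compound 1 by methyl in place of trifluoromethyl on an aromatic carbon. Among the measured compounds shown here, no measured step bears on this change, so the expectation is a step within the usual scatter, in no particular direction. For compound 4 the estimate is 30 nM, between 10 nM and 90 nM. The expected step, a 1.3-fold higher number from compound 1 to compound 4 (0.10 log units; within the scatter), is small.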

Compound 4, half-maximal inhibitory concentration: 12 nM
Beside the measured number, compound 4's estimate is 2.5-fold (0.40 log units) above it, within the range that was stated.
By their numbers in this assay, from the lowest: compound 2; then compounds 3, 4 and 1 (each within the scatter of the next, the first and the last beyond it).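

Putting methyl in place of trifluoromethyl gives a 2.0-fold lower number from compound 1 to compound 4 (0.30 log units; within the scatter) in this assay, so the two groups cannot be told apart at this place, on an aromatic carbon ortho to a large group. The three fluorine atoms can therefore go without a step beyond the scatter. Nothing available explains why the two groups read alike.

As far as these compounds go, whether a chlorine atom, a methoxy group or plain hydrogen at this place would also read the same stays open. So does whether a longer chain, such as ethyl, would keep the number.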